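The source may hold more compounds than are shown below. What is called first, only, known or untested is meant among the compounds shown, and "the series" means these compounds.

Measured in a functional assay on MDA-MB-231 cells (Homo sapiens) for cytotoxicity, read by MTT assay, with a stated time of 72 h; a lower number here means a stronger inhibitor, a higher number a weaker inhibitor:
- compound 1 `CN(C)Cc1ccc2nc(NC(=O)N/N=C/c3cn(Cc4ccccc4Cl)c4ccccc34)sc2c1`: 1180 nM
- compound 2 `CN(C)Cc1ccc2nc(NC(=O)N/N=C/c3c[nH]c4ccccc34)sc2c1`: 1190 nM
- compound 3 `Cc1ccc(Cn2cc(/C=N/NC(=O)Nc3nc4ccc(CN(C)C)cc4s3)c3ccccc32)cc1`: 1220 nM

Compound 1, at 1180 nM, stands level with the other two compounds, since all three values lie within the usual scatter of one another.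

Compound 4 `CC1CCN(Cc2ccc3nc(NC(=O)N/N=C/c4cn(Cc5ccccc5Cl)c5ccccc45)sc3c2)CC1` differs from compound 1 in one place: 4-methylpiperidin-1-yl in place of dimethylamino on a saturated chain carbon bound to an aromatic carbon. The dimethylamino group gives way to a 4-methylpiperidin-1-yl group, on a saturated chain carbon bound to an aromatic carbon.

The measured steps bear on this change only indirectly. They are a 1.0-fold higher number from compound 1 to compound 2 (0.00 log units; within the scatter), a 1.0-fold higher number from compound 1 to compound 3 (0.01 log units; within the scatter) and a 1.0-fold higher number from compound 2 to compound 3 (0.01 log units; within the scatter), all within the scatter. Each alters the group on the aromatic nitrogen, and the amine stays the same throughout. Among the compounds with values here, they show a flat response at that other place, but no measured compound varies the dimethylamino group. No step beyond the scatter is therefore expected in this assay, though with wide uncertainty.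

The expected change is a 1.1-fold lower number from compound 1 to compound 4 (0.05 log units; within the scatter). For compound 4 the estimated value is 1050 nM, with an expected range from 400 nM to 2600 nM.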

Compound 4, half-maximal inhibitory concentration: 1360 nM
Compound 4: the middle estimate sits 1.3-fold (0.11 log units) below what was measured, within the range that was stated.
By their numbers in this assay, from the lowest: compounds 1, 2, 3 and 4 (each within the scatter of the next).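

In this assay, replacing the dimethylamino group with the larger 4-methylpiperidin-1-yl group gives a 1.2-fold higher number from compound 1 to compound 4 (0.06 log units; within the scatter). A saturated chain carbon bound to an aromatic carbon can therefore carry this ring amine, with its greater number of heavy atoms, without a step beyond the scatter. Compound 1, compound 2 and compound 3 vary only the group on the aromatic nitrogen, so this is the only view of the amine end, and nothing measured here accounts for its flat response.

On these data alone, whether a morpholine ring, a primary amine or a carboxylic acid at this place would also stay within the scatter remains open. As far as these compounds go, it is also open whether 4-methylpiperidin-1-yl would give a similar result with hydrogen or 4-methylbenzyl on the aromatic nitrogen, as compound 4 carries 2-chlorobenzyl there.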